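A few compounds are considered here, and "the series" means these few. Any claim that something is new, unique, unknown or untested is made for them only; others in the source may bear on it.

The three measured compounds share one core and differ only in the group on the amine nitrogen of the piperazine ring. Compound 1 `Cn1c(-c2ccc(NC(=O)CN3CCN(c4ccccc4)CC3)cc2)nc(-c2ccccc2)c1-c1ccccc1` carries a phenyl there and in a functional assay on HT-29 cells (Homo sapiens) for cytotoxicity, read by MTT assay, with a stated time of 24 h, tested at 32 ug/mL (a lower number here means a weaker effect, a higher number a stronger effect of the compound at the concentration tested), compound 1 gives 60.5%. Compound 2 `Cn1c(-c2ccc(NC(=O)CN3CCN(Cc4ccccc4)CC3)cc2)nc(-c2ccccc2)c1-c1ccccc1` carries a benzyl and gives 40%; the change a number 20.5 percentage points lower from compound 1 to compound 2 (beyond the scatter). Compound 3 `Cc1ccc(CN2CCN(CC(=O)Nc3ccc(-c4nc(-c5ccccc5)c(-c5ccccc5)n4C)cc3)CC2)cc1` carries a 4-methylbenzyl and gives 42.3%, so a number 18.2 percentage points lower from compound 1 to compound 3 (beyond the scatter), while between the two benzyl compounds a number 2.3 percentage points higher from compound 2 to compound 3 (within the scatter). Compound 3 thus stands second highest of the three numbers, close to compound 2 and well under compound 1.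

Compound 4 `COc1ccc(CN2CCN(CC(=O)Nc3ccc(-c4nc(-c5ccccc5)c(-c5ccccc5)n4C)cc3)CC2)cc1` differs from compound 3 by methoxy in place of methyl on an aromatic carbon. Among the measured compounds shown here, no measured step involves a methoxy group; the only step that bears on the same position is the one from compound 2 to compound 3, which stayed within the scatter. A step of similar size is therefore expected here, with no clear direction: the expected step is a number 0.3 percentage points lower from compound 3 to compound 4 (within the scatter). Compound 4 is estimated to give about 42%, within a range from 30% to 55%.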

Compound 4, a percentage reported as activity, at one concentration (the size of the read-out at that concentration, not a potency): 29.9%
Estimate against measurement, compound 4: 12.1 percentage points above; measured number below the stated range.
By their numbers in this assay, from the lowest: compound 4; then compounds 2 and 3 (each within the scatter of the next); then compound 1.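

In this assay, the aromatic carbon of the benzyl group responds to substitution, but the outcome depends on the group that enters. Methyl in place of hydrogen gave a number 2.3 percentage points higher from compound 2 to compound 3 (within the scatter), whereas methoxy in place of methyl gave a number 12.4 percentage points lower from compound 3 to compound 4 (beyond the scatter) and methoxy in place of hydrogen gave a number 10.1 percentage points lower from compound 2 to compound 4 (beyond the scatter). With a number 30.6 percentage points lower from compound 1 to compound 4 (beyond the scatter), the 4-methoxybenzyl compound also lies furthest from the phenyl compound, and nothing available here accounts for the effect of the methoxy group.

The compounds shown leave open whether a 4-chlorobenzyl, 4-hydroxybenzyl or 4-aminobenzyl group would follow methoxy or methyl at this carbon. They also leave open whether methoxy would lower the read-out on another aromatic carbon of the benzyl group, or on the phenyl group of compound 1.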